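Removing the Amino Group from a Small Fused Core

The compounds below may be only part of what the source reports. "The series", "measured", "known", "first", "only" and "open" are said of these compounds alone.

Measured so far:
- compound 1 `Cc1cc2[nH]nc(N)c2c(=O)[nH]1`: 30%
- compound 2 `CC(C)(C)c1cc2[nH]nc(N)c2c(=O)[nH]1`: 39%

In an assay on isolated protein for inhibition of MAP kinase-activated protein kinase 2 (Homo sapiens), read by mobility shift assay, tested at 30 uM (on this read-out higher numbers stand for more inhibition at the one concentration tested (going by the name of the read-out) and lower numbers for less inhibition), compound 1 gives 30%, the lowest of the two numbers; its nearest neighbour is compound 2 with 39%, and the step of a number 9 percentage points higher from compound 1 to compound 2 (within the scatter) stays within the scatter, so the two cannot be told apart. That one step swaps tert-butyl for methyl on an aromatic carbon and says nothing about the amino group.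

Compound 3 `Cc1cc2[nH]ncc2c(=O)[nH]1` differs from compound 1 as follows: hydrogen in place of amino on an aromatic carbon. Within the data shown here, no measured step touches this group, so the expectation rests only on the low starting point of compound 1. The amino group is the only hydrogen-bond donor and acceptor removed, and taking it away is expected to lower the number somewhat, giving an estimated step of a number 15 percentage points lower from compound 1 to compound 3 (beyond the scatter). Compound 3 is therefore estimated at 15%, within a range from 0% to 35%.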

Compound 3, a percentage reported as inhibition, at one concentration (the size of the read-out at that concentration, not a potency): 11%
For compound 3 the middle estimate is 4 percentage points above the measured one, and the stated range covers the measured number.
By their numbers in this assay, from the lowest: compound 3; then compounds 1 and 2 (each within the scatter of the next).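

In this assay, putting hydrogen in place of amino on this aromatic carbon gives a number 19 percentage points lower from compound 1 to compound 3 (beyond the scatter). Among these compounds, this is the first change to move the number beyond the scatter, whereas the tert-butyl for methyl swap elsewhere on the core gave only a number 9 percentage points higher from compound 1 to compound 2 (within the scatter), so the read-out does respond to what sits at this position. No supporting data bear on why removing the amino group has this effect.

The compounds shown leave open whether a methylamino group, a hydroxyl group or a chlorine atom on this carbon would hold the number near that of compound 1 or let it fall towards that of compound 3. They also leave open whether removing the amino group from compound 2, which carries tert-butyl, would give a step of similar size.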